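A few compounds are considered here, and "the series" means these few. Any claim that something is new, unique, unknown or untested is made for them only; others in the source may bear on it.

Working notes on the series.

Going by the values given here, compound 3 `O=S(=O)(c1ccc(Cl)cc1)n1ccc2c(N3CCNCC3)c(Cl)ccc21` gives 6.31 nM in an assay on HeLa cells for displacement of a labelled ligand from 5-hydroxytryptamine receptor 6 (Homo sapiens) (on this read-out higher numbers stand for weaker inhibition and lower numbers for stronger inhibition), and so stands highest of the three numbers measured so far; its nearest and furthest neighbours, compound 1 `O=S(=O)(c1ccccn1)n1ccc2c(N3CCNCC3)cccc21` with 1 nM and compound 2 `O=S(=O)(c1ccccc1Cl)n1ccc2c(N3CCNCC3)c(Cl)ccc21` with 1 nM, both lie the same distance away, beyond the scatter. Among the compounds with values here, the one step within this set that is recorded as a single change is a 6.3-fold higher number from compound 2 to compound 3 (0.80 log units; beyond the scatter), which shows the 4-chlorophenyl group on the sulfonyl sulfur giving the weaker of the two numbers.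

Compound 4 `O=S(=O)(c1ccccn1)n1ccc2c(N3CCNCC3)c(Cl)ccc21` has not yet been measured. It differs from compound 3 in one place: pyridin-2-yl in place of 4-chlorophenyl on a sulfonyl sulfur. Within the data shown here, no measured step covers exactly this exchange. Two observations bear on it: the 4-chlorophenyl group is the least favourable sulfonyl substituent seen, as a 6.3-fold higher number from compound 2 to compound 3 (0.80 log units; beyond the scatter) shows, and the same pyridin-2-yl sulfonyl group as in compound 4 is already carried by compound 1, which gives 1 nM. Compound 1 differs from compound 4 elsewhere on the shared core. On that basis a lower number than compound 3 is expected for compound 4, roughly back to the level of compounds 1 and 2.

The estimate for compound 4 in this assay is 1.3 nM, with a range from 0.5 nM to 4 nM, which means an expected step of a 4.9-fold lower number from compound 3 to compound 4 (0.69 log units; beyond the scatter).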

Compound 4, inhibition constant: 0.501 nM
Estimate against measurement, compound 4: 2.6-fold (0.41 log units) above; the measured number falls inside the stated range.
By their numbers in this assay, from the lowest: compounds 4, 1 and 2 (each within the scatter of the next); then compound 3.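

Going by these compounds alone, with the core of compound 3 held fixed, pyridin-2-yl in place of 4-chlorophenyl on the sulfonyl sulfur gives a 13-fold lower number from compound 3 to compound 4 (1.10 log units; beyond the scatter) in this assay and so this is the largest step so far, which shows that the chloro on the aromatic carbon does not by itself carry the higher number of compound 3. Pyridin-2-yl and 2-chlorophenyl at this sulfonyl position cannot be told apart, with a 2.0-fold lower number from compound 2 to compound 4 (0.30 log units; within the scatter) on the same core, which leaves 4-chlorophenyl as the only one of the three groups there that stands apart. Chloro in place of hydrogen on an aromatic carbon can now be read as a single change, and it gives a 2.0-fold lower number from compound 1 to compound 4 (0.30 log units; within the scatter) for compounds carrying the pyridin-2-yl sulfonyl group, so no shift beyond the scatter is seen for this exchange.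

Nothing on hand explains why the 4-chlorophenyl group stands apart. From the compounds shown here alone, it remains open whether a plain phenyl, a 3-chlorophenyl or a 4-methoxyphenyl on the sulfonyl sulfur would follow compound 3 or compound 2, and whether a pyridin-3-yl group would match pyridin-2-yl.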